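A few compounds are considered here, and "the series" means these few. Any claim that something is new, unique, unknown or untested is made for them only; others in the source may bear on it.

Measured so far in an ADME assay on HeLa cells (Homo sapiens) for cytotoxicity, read by crystal violet staining, with a stated time of 72 h; a lower number here means that less compound is tolerated, a higher number that more compound is tolerated:
- compound 1 `CCOC(=O)c1cc(CCCOc2c(C)cc(-c3noc(C(F)(F)F)n3)cc2C)on1` | 17200 nM
- compound 2 `CCOC(=O)c1cc(CCCOc2ccc(-c3noc(C(F)(F)F)n3)cc2C)on1` | 35100 nM
- compound 3 `CNC(=O)c1cc(CCCOc2ccc(-c3noc(C(F)(F)F)n3)cc2C(F)(F)F)on1` | > 100000 nM (a limit)

Compound 2 gives 35100 nM, the higher of the two actual numbers in this assay. Its nearest neighbour is compound 1, and a 2.0-fold higher number from compound 1 to compound 2 (0.31 log units; beyond the scatter) is a modest move. Compound 3 stands at > 100000 nM, which is a limit of the assay and not a number.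

Next comes compound 4 `CCOC(=O)c1cc(CCCOc2ccc(-c3noc(C(F)(F)F)n3)cc2-n2cccc2)on1`, with 1H-pyrrol-1-yl in place of methyl on an aromatic carbon, ortho to a large group and meta to a 5-(trifluoromethyl)-1,2,4-oxadiazol-3-yl group: 1H-pyrrol-1-yl in place of methyl on an aromatic carbon. Within the data shown here, only one measured step bears on this, and only loosely. In a 2.0-fold higher number from compound 1 to compound 2 (0.31 log units; beyond the scatter), hydrogen replaces methyl on an aromatic carbon, so the smaller substituent goes with the higher number. Read in reverse for a larger substituent, that single step points to a modest drop. The expected change is a 2.2-fold lower number from compound 2 to compound 4 (0.34 log units; beyond the scatter), an estimate resting on that one step. For compound 4 the expected value is 16000 nM. The estimated range for compound 4 runs from 5000 nM to 50000 nM.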

Compound 4, half-maximal cytotoxic concentration: 57300 nM
Estimate against measurement, compound 4: 3.6-fold (0.55 log units) below; measured number above the stated range.
By their numbers in this assay, from the lowest: compound 1; then compounds 2 and 4 (each within the scatter of the next). At a limit, above all of these: compound 3.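

In this assay the new step reads a 1.6-fold higher number from compound 2 to compound 4 (0.21 log units; within the scatter), so the two compounds are not separated. This aromatic carbon, ortho to a large group and meta to a 5-(trifluoromethyl)-1,2,4-oxadiazol-3-yl group, therefore carries 1H-pyrrol-1-yl, with 5 heavy atoms and a five-membered aromatic ring, in place of methyl without a change beyond the scatter. The earlier methyl step was made at another aromatic carbon, and what it showed does not carry over to this one, while nothing measured here bears on why this larger group leaves the number in place.

Open, going by these compounds, is whether an amine, a carboxylic acid or a longer alkyl chain at this same aromatic carbon would also leave the number in place. Also open, on these data alone, is whether the 1H-pyrrol-1-yl result would hold if the ethyl ester were replaced by the methyl amide of compound 3.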